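Compound 4 Carries a Hydroxycyclopentyl Group on Sulfur

The source may hold more compounds than are shown below. What is called first, only, known or untested is meant among the compounds shown, and "the series" means these compounds.

Compound 3 `CC(C)c1n[nH]c2c(NCc3ccc(-c4ccccn4)cc3)nc(SCC(C)(C)O)nc12` gives 507 nM in a functional assay on HT cells (Homo sapiens) for antiproliferative activity, read by fluorescence, with a stated time of 72 h (on this read-out lower numbers stand for stronger inhibition of growth and higher numbers for weaker inhibition of growth), the highest of the three numbers measured, while compound 1 `CC(C)c1n[nH]c2c(NCc3ccc(-c4ccccn4)cc3)nc(SCC(O)CN3CCNCC3)nc12` gives 332 nM and compound 2 `CC(O)CSc1nc(NCc2ccc(-c3ccccn3)cc2)c2[nH]nc(C(C)C)c2n1` gives 62 nM. The two measured steps that reach compound 3 are a 1.5-fold higher number from compound 1 to compound 3 (0.18 log units; within the scatter) and an 8.2-fold higher number from compound 2 to compound 3 (0.91 log units; beyond the scatter). Compound 4 `CC(C)c1n[nH]c2c(NCc3ccc(-c4ccccn4)cc3)nc(SC3CCCC3O)nc12` differs from compound 3 by 2-hydroxycyclopentyl in place of 2-hydroxy-2-methylpropyl on a sulfur. Neither measured step resembles this change, which brings in a five-membered ring rather than adding or removing a single substituent, so its direction is uncertain. The step for compound 4 is expected to be a 2.0-fold lower number from compound 3 to compound 4 (0.31 log units; beyond the scatter), no larger than the modest steps already seen. The estimate for compound 4 is 250 nM, with a range from 80 nM to 800 nM.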

Compound 4, concentration for 50% growth inhibition: 567 nM
The estimate for compound 4 lay 2.3-fold (0.36 log units) below the measured number, and the stated range covers the measured number.
By their numbers in this assay, from the lowest: compound 2; then compounds 1, 3 and 4 (each within the scatter of the next).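

In this assay the ring-closed 2-hydroxycyclopentyl on the sulfur shows a 1.1-fold higher number from compound 3 to compound 4 (0.05 log units; within the scatter) and so cannot be told apart from the open 2-hydroxy-2-methylpropyl, while a 1.7-fold higher number from compound 1 to compound 4 (0.23 log units; within the scatter) places it equally close to the piperazine-bearing chain. Set against the 2-hydroxypropyl group, the same ring shows a 9.1-fold higher number from compound 2 to compound 4 (0.96 log units; beyond the scatter) and so, like the added methyl of compound 3, stands apart from compound 2. Going by these compounds, whether a six-membered carbon ring or an amine on the cyclopentyl ring would come closer to compound 2 stays open. Nothing available explains these numbers.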